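The compounds below may be only part of what the source reports. "The series", "measured", "known", "first", "only" and "open" are said of these compounds alone.

Measured so far:
compound 1 `O=C(Nc1ccc(Cl)c(-c2nnc3c(Cl)cccn23)c1)c1ccc(F)cc1Cl` — in a functional assay on A549 cells (Homo sapiens) for antiproliferative activity, read by MTT assay, with a stated time of 72 h (on this read-out higher numbers stand for weaker inhibition and lower numbers for stronger inhibition), compound 1 gives > 100000 nM, a limit of the assay.
compound 2 `O=C(Nc1ccc(Cl)c(-c2nnc3c(Cl)cccn23)c1)c1cccnc1` — in this assay compound 2 gives > 100000 nM, a limit of the assay.
compound 3 `CS(=O)(=O)c1ccc(C(=O)Nc2ccc(Cl)c(-c3nnc4c(Cl)cccn34)c2)cc1` — in this assay compound 3 gives > 100000 nM, a limit of the assay.

Compound 3 thus stands only at a limit, and the same holds for both other measured compounds: the limit of > 100000 nM in this assay, at which 3 of the 3 values shown sit. No value in the set is a number. The three steps among them, a step that the two limits leave unreadable from compound 1 to compound 2, a step that the two limits leave unreadable from compound 1 to compound 3 and a step that the two limits leave unreadable from compound 2 to compound 3, are therefore all unreadable in size and direction, and nothing in the data separates the three compounds.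

Compound 4 `O=C(Nc1ccc(Cl)c(-c2nnc3c(Cl)cccn23)c1)c1ccc(Cl)cc1Cl` is not yet measured. It differs from compound 3 in one place: 2,4-dichlorophenyl in place of 4-(methylsulfonyl)phenyl on a carbonyl carbon. Going by the values given here, no measured step bears on this exchange directly. Among the compounds with values here, what can be said is that compound 1, which carries 2-chloro-4-fluorophenyl on the same carbonyl carbon, also sits at the limit in this assay, and no step moves off that limit.

Compound 4 is accordingly expected to remain at or near the limit in this assay, with an estimate of 100000 nM and a range from 30000 nM to 300000 nM. The expected step of a number no higher from compound 3 to compound 4 (the limit leaves the size open) is none beyond the scatter.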

Compound 4, half-maximal inhibitory concentration: 61300 nM
The estimate for compound 4 lay 1.6-fold (0.21 log units) above the measured number; low and high end bracket the measured number.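

Compound 4, with 2,4-dichlorophenyl on the carbonyl carbon whose other neighbour is the amide-type nitrogen, is the only compound shown that gives a number rather than a limit in this assay, so a group at this place can bring the series off the limit. The three steps to it are floors only, an at least 1.6-fold lower number from compound 3 to compound 4 (0.21 log units; that floor lies within the scatter), an at least 1.6-fold lower number from compound 2 to compound 4 (0.21 log units; that floor lies within the scatter) and an at least 1.6-fold lower number from compound 1 to compound 4 (0.21 log units; that floor lies within the scatter), and each floor lies within the scatter; the last of these, chloro in place of fluoro on an aromatic carbon, is the smallest exchange in the set, and its real size may be small or large. The steps among compound 1, compound 2 and compound 3 still cannot be read, and those three compounds remain unseparated: the limit of > 100000 nM in this assay, at which 3 of the 4 values shown sit.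

From the compounds shown here alone, how far each of the three steps extends past its floor stays open, as does whether the number for compound 4 reflects the second chloro group specifically or the 2,4-dichlorophenyl group as a whole. Also open, going by these compounds, is how this assay responds at this carbonyl carbon to a 2,4-dibromophenyl group, a 3,4-dichlorophenyl group or a saturated amine such as a piperidine.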